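A few compounds are considered here, and "the series" means these few. Any claim that something is new, unique, unknown or untested is made for them only; others in the source may bear on it.

Of the compounds shown here, three of one shared core have been measured in a functional assay on A-375 cells (Homo sapiens) for antiproliferative activity, read by CCK-8 assay, with a stated time of 72 h, tested at 8 uM; on this read-out higher numbers stand for a stronger effect at the one concentration tested and lower numbers for a weaker effect. Compound 1 `Nc1ccccc1NC(=O)c1ccc(CSC(=S)N2CCN(c3ccc(Cl)cc3)CC2)cc1` gives 29%, compound 2 `Nc1ccccc1NC(=O)c1ccc(CSC(=S)N2CCN(c3ccc(F)cc3)CC2)cc1` gives 76.3%, and compound 3 `Nc1ccccc1NC(=O)c1ccc(CSC(=S)N2CCN(c3ncccn3)CC2)cc1` gives 67.9%. Compound 3 thus lies well above compound 1, by the step of a number 38.9 percentage points higher from compound 1 to compound 3 (beyond the scatter), while its gap to compound 2 falls within the scatter. Compound 4 `Nc1ccccc1NC(=O)c1ccc(CSC(=S)N2CCN(Cc3ccccc3)CC2)cc1` differs from compound 3 by benzyl in place of pyrimidin-2-yl on an amine nitrogen in a ring. Among the measured compounds shown here, no measured step swaps these two groups. For the measured compounds named here, the steps of a number 47.3 percentage points higher from compound 1 to compound 2 (beyond the scatter) and a number 38.9 percentage points higher from compound 1 to compound 3 (beyond the scatter) show only that changes at this ring nitrogen can move the read-out a great deal. The expected step of a number 12.9 percentage points lower from compound 3 to compound 4 (beyond the scatter) therefore carries no firm direction. Compound 4 is estimated at 55%, with a range from 25% to 80%.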

Compound 4, a percentage reported as inhibition, at one concentration (the size of the read-out at that concentration, not a potency): 29.3%
The estimate for compound 4 lay 25.7 percentage points above the measured number, within the range that was stated.
By their numbers in this assay, from the lowest: compounds 1 and 4 (each within the scatter of the next); then compounds 3 and 2 (each within the scatter of the next).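

Benzyl on this ring nitrogen brings a large fall, with a number 38.6 percentage points lower from compound 3 to compound 4 (beyond the scatter) and a number 47 percentage points lower from compound 2 to compound 4 (beyond the scatter) so an aromatic ring on this nitrogen does not by itself keep the read-out high. Against 4-chlorophenyl there is no readable change, with a number 0.3 percentage points higher from compound 1 to compound 4 (within the scatter) so these two groups share the low level, and ring nitrogens do not sort the set, since compound 2 stays high with a carbon-only ring. Nothing available explains these gaps. Still open, from the compounds shown here alone, is how a plain phenyl, a pyridin-2-yl or a 2-phenylethyl group would behave on this nitrogen.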